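A few compounds are considered here, and "the series" means these few. Any claim that something is new, unique, unknown or untested is made for them only; others in the source may bear on it.

Measured in a functional assay on HCT-15 cells (Homo sapiens) for cytotoxicity, in the presence of a further agent that is not named here; on this read-out lower numbers stand for stronger inhibition and higher numbers for weaker inhibition:

Compound 1 `Clc1ccc(-c2cc(-c3ccsc3)nc(-c3ccccc3Cl)c2)o1`: 4570 nM
Compound 2 `Clc1ccc(-c2cc(-c3ccco3)nc(-c3cccs3)c2)o1`: > 50000 nM, a limit
Compound 3 `Clc1ccc(-c2cc(-c3ccoc3)cc(-c3ccsc3)n2)cc1`: > 100000 nM, a limit

For the measured compounds named here, compound 1 stands alone in this set as the only compound with an actual number, 4570 nM. Compound 2 reached only a limit of the assay, > 50000 nM. Compound 3 likewise reached only a limit, > 100000 nM. Going by the values given here, no step between measured compounds that differ in one place is available, so the three results can only be set side by side. Of these three compounds, only compound 1 carries the 2-chlorophenyl group.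

Compound 4 `Clc1ccc(-c2cc(-c3cccnc3)nc(-c3ccsc3)c2)o1` has not yet been measured in this assay. It keeps the 5-chlorofuran-2-yl and thiophen-3-yl groups of compound 1 but has pyridin-3-yl in place of 2-chlorophenyl on an aromatic carbon. Among the compounds with values here, that group is the one compound 4 loses, and the only numerical result here belongs to compound 1 at 4570 nM, so the expectation leans towards weaker inhibition. The expected change is a 4.4-fold higher number from compound 1 to compound 4 (0.64 log units; beyond the scatter), a step clearly beyond the usual scatter but uncertain in size. A result reported only as a limit would also not be surprising. For compound 4 the estimated value is 20000 nM, with an expected range from 5000 nM to 70000 nM.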

Compound 4, half-maximal inhibitory concentration: > 50000 nM
Compound 4 ended at the assay's limit; the forecaster's own chance of this, stated with the estimate: 40%; middle value at least 2.5-fold (0.39 log units) from the limit.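

For the compounds shown here, compounds 1 and 4 are the first pair here that differ in one place only, so this position can now be read on its own, with the 5-chlorofuran-2-yl and thiophen-3-yl groups held constant. In this assay, putting pyridin-3-yl in place of 2-chlorophenyl, on the aromatic carbon next to the ring nitrogen, gives an at least 10-fold higher number from compound 1 to compound 4 (1.03 log units; beyond the scatter) and this large step lies beyond the scatter. From the compounds shown here alone, the true size of the step stays unknown because compound 4 gives no number, only an assay limit shared with one other compound: the limit of > 50000 nM in this assay, at which 2 of the 4 values shown sit.

The compounds shown leave open whether the 4570-level activity of compound 1 depends on the chlorine, on the carbon-only ring, or on both, and a plain phenyl group or a 2-methylphenyl group at this position would separate those two parts of the change. They also leave open how much further the value of compound 4 lies past its limit, and whether the same exchange would have a comparable effect with other groups on the shared core.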